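Shifting the chlorothiophenyl attachment point in the ether series

A few compounds are considered here, and "the series" means these few. Any claim that something is new, unique, unknown or untested is made for them only; others in the source may bear on it.

Among the measured compounds shown here, compound 3 `Cn1c(C2CC2)nc2ccc(-n3ccc(OCc4ccc(Cl)s4)cc3=O)cc21` gives 11 nM in an assay on CHO cells for displacement of a labelled ligand from melanin-concentrating hormone receptor 1 (Rattus norvegicus), read by scintillation counting, with a stated time of 1 h (on this read-out lower numbers stand for stronger inhibition and higher numbers for weaker inhibition), the lowest of the three numbers so far, although its gap to compound 1 is within the scatter. Compound 1 `Cn1c(C2CC2)nc2ccc(-n3ccc(OCc4ccc(Cl)cc4)cc3=O)cc21` gives 21 nM; a 1.9-fold lower number from compound 1 to compound 3 (0.28 log units; within the scatter). Compound 2 `Cn1c(C2CC2)nc2ccc(-n3ccc(OCc4ccccc4Cl)cc3=O)cc21` gives 140 nM; a 13-fold lower number from compound 2 to compound 3 (1.10 log units; beyond the scatter) and a 6.7-fold higher number from compound 1 to compound 2 (0.82 log units; beyond the scatter). Compound 4 `Cn1c(C2CC2)nc2ccc(-n3ccc(OCc4csc(Cl)c4)cc3=O)cc21` differs from compound 3 by 5-chlorothiophen-3-yl in place of 5-chlorothiophen-2-yl on a saturated chain carbon bound to an oxygen on an aromatic ring. For the measured compounds named here, no measured step moves the attachment point of a thiophenyl group; the only comparison is the shift from 4-chlorophenyl to 2-chlorophenyl, a 6.7-fold higher number from compound 1 to compound 2 (0.82 log units; beyond the scatter), which was modest and unfavourable. A shift of attachment is therefore expected to raise the number moderately, a 2.7-fold higher number from compound 3 to compound 4 (0.44 log units; beyond the scatter), with wide uncertainty. Compound 4 is estimated at 30 nM, range 10 nM to 90 nM.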

Compound 4, half-maximal inhibitory concentration: 9.3 nM
Compound 4: middle estimate off by 3.2-fold (0.51 log units), on the high side; the whole stated range lies above it.
By their numbers in this assay, from the lowest: compounds 4, 3 and 1 (each within the scatter of the next, the first and the last beyond it); then compound 2.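

Exchanging 5-chlorothiophen-2-yl for 5-chlorothiophen-3-yl gives no readable difference in this assay: a 1.2-fold lower number from compound 3 to compound 4 (0.07 log units; within the scatter). Compound 4 also separates from both chlorophenyl ethers, with a 2.3-fold lower number from compound 1 to compound 4 (0.35 log units; beyond the scatter) and a 15-fold lower number from compound 2 to compound 4 (1.18 log units; beyond the scatter), whereas the gap from compound 1 to compound 3 stayed within the scatter. Nothing available bears on why the two thiophene attachments read alike.

As far as these compounds go, it remains open whether 5-chlorothiophen-3-yl keeps this number with a methyl or a nitrile in place of the chlorine. Also open, from the compounds shown here alone, is how a longer chain in place of the single saturated carbon would read.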